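The compounds below may be only part of what the source reports. "The series", "measured", "known", "first", "only" and "open" are said of these compounds alone.

Measured so far in a functional assay on A549 cells (Homo sapiens) for cytotoxicity, read by MTT assay, with a stated time of 4 h; a higher number here means a weaker inhibitor, a lower number a stronger inhibitor:
- compound 1, `COc1ccc(/C=C2/SC(NN3Cc4ccccc4N=C3c3ccccc3)=NC2=O)cc1OC`: compound 1 gives 44700 nM
- compound 2, `O=C1N=C(NN2Cc3ccccc3N=C2c2ccccc2)S/C1=C/c1ccccc1`: compound 2 gives 720 nM
- compound 3, `CCc1ccc(NCC(=O)Nn2c(-c3ccccc3)nc3ccccc3c2=O)cc1`: compound 3 gives 2100 nM

Compound 2 has the lowest number of the three in this assay. Compound 3 is its nearest neighbour, with a higher number that lies beyond the scatter, and compound 1 stands furthest from it, far above. For the measured compounds named here, the one step measured within the shared core is a 62-fold lower number from compound 1 to compound 2 (1.79 log units; beyond the scatter), a large drop when the two methoxy groups on the 3,4-dimethoxyphenyl were removed.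

Compound 4, `COc1ccc(/C=C2/SC(NN3Cc4ccccc4N=C3c3ccccc3)=NC2=O)cc1`, is not yet measured. Its difference from compound 2 is methoxy in place of hydrogen on an aromatic carbon; cut one bond further out it reads phenyl to 4-methoxyphenyl. This puts back one of the two methoxy groups whose removal gave the step from compound 1 to compound 2, so that step bears on it directly. A rise in the number is therefore expected in this assay, probably smaller than the measured step, since only one methoxy enters.

For compound 4 the expected value in this assay is 5000 nM, with a range from 1500 nM to 20000 nM, which corresponds to an expected step of a 6.9-fold higher number from compound 2 to compound 4 (0.84 log units; beyond the scatter).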

Compound 4, half-maximal inhibitory concentration: 5310 nM
Estimate against measurement, compound 4: 1.1-fold (0.03 log units) below, and the stated range covers the measured number.
By their numbers in this assay, from the lowest: compound 2; then compound 3; then compound 4; then compound 1.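

In this assay, the large drop seen earlier now resolves into two separate parts: adding a single methoxy to the phenyl gives a 7.4-fold higher number from compound 2 to compound 4 (0.87 log units; beyond the scatter), and removing the other methoxy of the 3,4-dimethoxyphenyl gives an 8.4-fold lower number from compound 1 to compound 4 (0.93 log units; beyond the scatter). Both steps are modest and beyond the scatter, so the 4-methoxyphenyl of compound 4 lies between the phenyl and the 3,4-dimethoxyphenyl, and each methoxy goes with a higher number in this series. No supporting data bear on why the number rises with either methoxy.

As far as these compounds go, it remains open whether this rise is particular to methoxy or would also follow from a hydroxy, chloro or dimethylamino group at the same place. Also open, from the compounds shown here alone, is how a phenyl carrying only the other methoxy of the 3,4-dimethoxyphenyl would compare.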